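This account rests on a few compounds, and the source may have more. Where it says the series, first, only, none or still open, it means among the compounds named here.

Compound 1 `O=C(COc1ccc(Oc2ccccc2)cc1)Cn1ncc2ccccc21` gives 2600 nM in an assay on microsomes from brain for inhibition of Fatty-acid amide hydrolase 1 (Rattus norvegicus), read by fluorescence and HPLC, with a stated time of 45 min; a higher number here means a weaker inhibitor, a lower number a stronger inhibitor. Compound 2 `O=C(COc1ccc(Oc2ccccc2)cc1)Cn1ncc2cc([N+](=O)[O-])ccc21` gives 550 nM in this assay, the lowest of the two numbers, and the step of a 4.7-fold lower number from compound 1 to compound 2 (0.67 log units; beyond the scatter) shows that a change at this aromatic carbon is felt. Compound 3 `O=C(COc1ccc(Oc2ccccc2)cc1)Cn1ncc2cc(NC(=O)NC3CCCCC3)ccc21` differs from compound 2 by (cyclohexylcarbamoyl)amino in place of nitro on an aromatic carbon. Among the measured compounds shown here, only that one modest step bears on the position, and it cannot say how a much larger group will behave. Compound 3 is therefore expected to give 200 nM in this assay, with a range of 30 nM to 1500 nM, an expected step of a 2.8-fold lower number from compound 2 to compound 3 (0.44 log units; beyond the scatter).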

Compound 3, half-maximal inhibitory concentration: 840 nM
Beside the measured number, compound 3's estimate is 4.2-fold (0.62 log units) below it; low and high end bracket the measured number.
By their numbers in this assay, from the lowest: compounds 2 and 3 (each within the scatter of the next); then compound 1.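

The step of a 1.5-fold higher number from compound 2 to compound 3 (0.18 log units; within the scatter) shows that in this assay this aromatic carbon accepts (cyclohexylcarbamoyl)amino, with its six-membered ring and 10 heavy atoms, in place of nitro with no difference that can be told apart. The step of a 3.1-fold lower number from compound 1 to compound 3 (0.49 log units; beyond the scatter) shows that this larger group, like nitro, also separates from hydrogen. Nothing measured here gives a reason for either step. On these data alone, it remains open whether a plain amine, or a phenyl ring in place of the cyclohexyl ring, would match these two groups, and whether other aromatic carbons of the shared core respond alike.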